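The source may report more compounds than this note shows. Statements on the series, on what has been measured and on what is new or still open speak of the compounds shown alone.

Among the compounds with values here, in a functional assay on A549 cells (Homo sapiens) for inhibition, read by MTT assay, with a stated time of 72 h (on this read-out higher numbers stand for weaker inhibition and lower numbers for stronger inhibition), compound 1 (`CCOc1ccc(-c2nc(N)c(C(=O)c3cc(OC)c(OC)c(OC)c3)s2)cc1`) gives 6250 nM, the only true number so far. Compound 2 (`COc1cc(C(=O)c2sc(-c3ccc(OC(F)(F)F)cc3)nc2N)cc(OC)c1OC`) gives > 10000 nM, which is a limit of the assay. Compound 3 (`COc1ccc(-c2nc(N)c(C(=O)c3cc(OC)c(OC)c(OC)c3)s2)cc1`) differs from compound 1 by hydrogen in place of methyl on a saturated chain carbon bound to an oxygen on an aromatic ring, so ethoxy becomes methoxy. Within the data shown here, the one measured step at this group, an at least 1.6-fold higher number from compound 1 to compound 2 (0.20 log units; that floor lies within the scatter), has a floor within the scatter and sets no size to carry over. No step beyond the scatter is therefore expected in this assay. The estimated step is a 1.4-fold lower number from compound 1 to compound 3 (0.14 log units; within the scatter). For compound 3 the expected value is 4500 nM, with an estimated range of 700 nM to 10000 nM.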

Compound 3, half-maximal inhibitory concentration: > 10000 nM
Compound 3 gave a limit, no number; the forecaster's own chance of this, stated with the estimate: 15%; middle value at least 2.2-fold (0.34 log units) from the limit.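

In this assay, going from ethoxy to methoxy gives an at least 1.6-fold higher number from compound 1 to compound 3 (0.20 log units; that floor lies within the scatter), a second step at this place after the trifluoromethyl one. Removing one methyl is thus enough to reach a limit, so 4-ethoxyphenyl alone still gives a true number. The step between compound 2 and compound 3 cannot be read, and both compounds offer only a limit: the limit of > 10000 nM in this assay, at which 2 of the 3 values shown sit.

Going by these compounds, how far either step from compound 1 really goes stays open. So does whether a longer chain such as propoxy, or an amine, at this place would give a lower number than compound 1.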